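The compounds below may be only part of what the source reports. "The series", "measured", "known", "first", "only" and "open" are said of these compounds alone.

Compounds measured so far:
- compound 1 `CCn1cnc2c(-c3ccc(F)c(OCc4ccccn4)c3)cnnc21`: 41 mL.min-1.g-1
- compound 2 `CCn1cnc2c(-c3ccc(F)c(-c4cccc(C(=O)NC)c4)c3)cnnc21`: 40 mL.min-1.g-1

In an ADME assay on microsomes from liver (Homo sapiens) for metabolic stability (a higher number here means faster removal of the compound, a lower number slower removal), compound 2 and compound 1 lie within the usual scatter of each other, so these numbers do not separate them. Compound 3 `CCn1cnc2c(-c3ccc(F)c(-c4cc(C(=O)NC)ccc4F)c3)cnnc21` keeps the structure of compound 2 but carries fluoro in place of hydrogen on an aromatic carbon. The new group sits ortho to a large group and para to a methylcarbamoyl group. For the measured compounds named here, no two measured compounds differ in only one place, so the data do not show directly what this change does. The expectation therefore stays close to compound 2 at 40 mL.min-1.g-1, with no step beyond the scatter in this assay. The estimated step is a 1.1-fold lower number from compound 2 to compound 3 (0.02 log units; within the scatter). For compound 3, the expected value is 38 mL.min-1.g-1, with an expected range of 20 mL.min-1.g-1 to 70 mL.min-1.g-1.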

Compound 3, intrinsic clearance in microsomes in the Homo sapiens assay: 34 mL.min-1.g-1
For compound 3 the middle estimate is 1.1-fold (0.05 log units) above the measured one, within the range that was stated.
By their numbers in the Homo sapiens assay, from the lowest: compounds 3, 2 and 1 (each within the scatter of the next).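

For the compounds shown here, compound 2 and compound 3 form the first pair here that differs in only one place, so fluoro in place of hydrogen on an aromatic carbon can now be read directly, ortho to a large group and para to a methylcarbamoyl group, and in a physicochemical assay for lipophilicity (a lower number here means a more polar compound, a higher number a more lipophilic compound), compound 2 gives 2.8 and compound 3 gives 3. In the Homo sapiens assay the result is a 1.2-fold lower number from compound 2 to compound 3 (0.07 log units; within the scatter), and in the physicochemical assay it is a number 0.20 log units higher from compound 2 to compound 3 (within the scatter), so neither read-out separates the two compounds at this position. Nothing available here explains either result.

The compounds shown leave open whether fluoro at another carbon of this ring would also stay within the scatter. They also leave open whether a different group at this same position, such as chloro, methoxy or an amine, would give a step beyond it.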